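The source may report more compounds than this note shows. Statements on the series, on what has been measured and on what is new or still open speak of the compounds shown alone.

Two compounds here carry a measured number. In a functional assay on K562 cells (Homo sapiens) for cytotoxicity, read by trypan blue exclusion, with a stated time of 96 h (on this read-out higher numbers stand for weaker inhibition and lower numbers for stronger inhibition), compound 1 `COc1ccc(NS(=O)(=O)/C=C/c2cc(OC)c(OC)c(OC)c2)cc1` gives 35000 nM, while compound 2 `COC(=O)C(C)(C)Nc1cc(NS(=O)(=O)/C=C/c2c(OC)cc(OC)cc2OC)ccc1OC` gives 300 nM, the lower of the two numbers and the stronger of the pair, a gap that stands well beyond the scatter. Compound 3 `COc1cc(OC)c(/C=C/S(=O)(=O)Nc2ccc(OC)c(NC(C(=O)O)c3ccc(Cl)cc3)c2)c(OC)c1` awaits measurement. It differs from compound 2 in one place: carboxy(4-chlorophenyl)methyl in place of 1-(methoxycarbonyl)-1-methylethyl on a nitrogen on an aromatic ring. Going by the values given here, no measured pair bears on a change of this kind, so the expectation rests on compound 2 alone. A modest step toward weaker inhibition is expected, a 2.7-fold higher number from compound 2 to compound 3 (0.43 log units; beyond the scatter). Compound 3 is estimated at 800 nM, within 150 nM to 5000 nM.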

Compound 3, half-maximal inhibitory concentration: 15 nM
Compound 3: middle estimate off by 53-fold (1.73 log units), on the high side; the measured number lies below the stated range.
By their numbers in this assay, from the lowest: compound 3; then compound 2; then compound 1.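

This position on the nitrogen on an aromatic ring accepts a much larger group with a gain: in this assay, carboxy(4-chlorophenyl)methyl in place of 1-(methoxycarbonyl)-1-methylethyl gives a 20-fold lower number from compound 2 to compound 3 (1.30 log units; beyond the scatter). The change brings in an aromatic ring and a hydrogen-bond donor, and it replaces the ester with a free carboxy group, all in one step. Nothing shown explains the gain. The compounds shown leave open which of these parts carries the step. Carboxy(phenyl)methyl or the methyl ester of carboxy(4-chlorophenyl)methyl at this nitrogen would separate them.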